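Benzyloxy in place of ethoxy on the ester compound

The compounds below may be only part of what the source reports. "The series", "measured", "known", "first", "only" and "open" are said of these compounds alone.

Among the measured compounds shown here, compound 3 `CCOC(=O)c1cnc(-c2ccccc2OCC)[nH]c1=O` stands highest of the three numbers measured so far: in a functional assay on the whole organism (strain Sprague-Dawley) for inhibition, with Rattus norvegicus as the target, with a stated time of 10 min (a lower number here means that less compound is needed, a higher number that more compound is needed for the effect), compound 3 gives 2 mg/kg. The step of a 4.0-fold higher number from compound 1 to compound 3 (0.60 log units; beyond the scatter) separates it from compound 1 `CCOc1ccccc1-c1ncc(C(=O)O)c(=O)[nH]1`, which gives 0.5 mg/kg. Compound 2 `CCCCOc1ccccc1-c1ncc(C(=O)O)c(=O)[nH]1` gives 0.5 mg/kg.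

Compound 4 `CCOC(=O)c1cnc(-c2ccccc2OCc2ccccc2)[nH]c1=O` differs from compound 3 by phenyl in place of methyl on a saturated chain carbon bound to an oxygen on an aromatic ring. For the measured compounds named here, the only measured step at that same chain is no change at the digits printed from compound 1 to compound 2 (within the scatter), where lengthening the chain left the number unchanged; the step of a 4.0-fold higher number from compound 1 to compound 3 (0.60 log units; beyond the scatter) sits at the ester and does not bear on this change. A phenyl is a larger entry than an ethyl, so some uncertainty remains, but the expectation is no step beyond the scatter, namely no change at the digits printed from compound 3 to compound 4 (within the scatter). Compound 4 is therefore estimated to give 2 mg/kg in this assay, with a range from 0.8 mg/kg to 5 mg/kg.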

Compound 4, dose for 50% inhibition: > 5 mg/kg
Compound 4: no number, only a limit; the forecaster's own chance of this, stated with the estimate: 5%; middle value at least 2.5-fold (0.39 log units) from the limit.
By their numbers in this assay, from the lowest: compounds 1 and 2 (each within the scatter of the next); then compound 3. At a limit, above all of these: compound 4.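

Compound 4 carries no number in this assay, only a limit: the limit of > 5 mg/kg in this assay, at which 1 of the 4 values shown sits.

Even so, the step is readable as an at least 2.5-fold higher number from compound 3 to compound 4 (0.39 log units; beyond the scatter), the first change at this chain to lie beyond the scatter, whereas the earlier change on the carboxylic acid gave no change at the digits printed from compound 1 to compound 2 (within the scatter). So this chain position does not tolerate every larger group, at least with the ethyl ester in place.

The compounds shown leave open whether a butoxy chain on the ethyl ester would also raise the number, and whether benzyloxy would do so with the free carboxylic acid.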